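Fluoro to hydrogen on the benzoyl ring of compound 2

This account rests on a few compounds, and the source may have more. Where it says the series, first, only, none or still open, it means among the compounds named here.

Compound 2 `CCN1CCN(c2cc(C)c3cc(NC(=O)c4cccc(F)c4)ccc3n2)CC1` stands highest of the three numbers in a functional assay on SK-BR-3 cells (Homo sapiens) for antiproliferative activity, read by MTT assay, with a stated time of 72 h (on this read-out lower numbers stand for stronger inhibition and higher numbers for weaker inhibition), where compound 2 gives 24900 nM. Compound 3 `Cc1cc(NCCN2CCCC2)nc2ccc(NC(=O)c3ccc(Cl)c(Cl)c3)cc12` is nearest with 9530 nM, and compound 1 `Cc1cc(NCCN2CCN(C)CC2)nc2ccc(NC(=O)c3ccc(Cl)c(Cl)c3)cc12` lies furthest with 2690 nM. Going by the values given here, the only measured step, a 3.5-fold higher number from compound 1 to compound 3 (0.55 log units; beyond the scatter), alters the group on the saturated chain carbon rather than the benzoyl ring, so it does not bear on the change at hand. Compound 4 `CCN1CCN(c2cc(C)c3cc(NC(=O)c4ccccc4)ccc3n2)CC1` differs from compound 2 only as hydrogen in place of fluoro on an aromatic carbon. Among the compounds with values here, no measured pair in this set isolates that change, so no step beyond the scatter is expected in this assay in either direction. Compound 4 is therefore estimated at 25000 nM, within a range of 10000 nM to 60000 nM, which is expected to amount to a 1.0-fold higher number from compound 2 to compound 4 (0.00 log units; within the scatter).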

Compound 4, half-maximal inhibitory concentration: 18400 nM
Compound 4: middle estimate off by 1.4-fold (0.13 log units), on the high side; low and high end bracket the measured number.
By their numbers in this assay, from the lowest: compound 1; then compounds 3, 4 and 2 (each within the scatter of the next, the first and the last beyond it).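

In this assay, going by these compounds alone, hydrogen in place of fluoro on the aromatic carbon meta to a large group gives a 1.4-fold lower number from compound 2 to compound 4 (0.13 log units; within the scatter), the first reading of any change on this ring position. In this pair, the 3-fluorophenyl and phenyl forms therefore cannot be told apart, and the fluoro is not needed to hold the number at this level. Nothing measured here bears on why the change has so little effect.

Going by these compounds, whether a methoxy group or an amine on the same ring carbon would move the number remains open. So does whether fluoro and hydrogen would also read alike with the side chain of compound 1.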